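The source may hold more compounds than are shown below. What is called first, only, known or untested is meant among the compounds shown, and "the series" means these compounds.

Compound 1 `COc1ccc(/C=C\c2cc(OC)c(OC)c(OC)c2)cc1OCc1ccc(C=O)cc1` carries a formyl group on the outer ring of the shared core. Among the measured compounds shown here, in a functional assay on HeLa cells (Homo sapiens) for antiproliferative activity, read by CCK-8 assay, with a stated time of 48 h (on this read-out lower numbers stand for stronger inhibition and higher numbers for weaker inhibition), compound 1 gives 4800 nM, which is the only plain number among the three compounds measured so far. Compound 2 `COc1ccc(/C=C\c2cc(OC)c(OC)c(OC)c2)cc1OCc1ccc(CN2CCCC[C@H]2C(=O)O)cc1` is measured in this assay only as a limit, > 10000 nM. Compound 3 `COc1ccc(/C=C\c2cc(OC)c(OC)c(OC)c2)cc1OCc1ccc(CN2CC[C@@H](O)C2)cc1` is likewise measured in this assay only as a limit, > 10000 nM. The two steps that leave the formyl group, an at least 2.0-fold higher number from compound 1 to compound 2 (0.31 log units; beyond the scatter) and an at least 2.0-fold higher number from compound 1 to compound 3 (0.31 log units; beyond the scatter), therefore both end at the limit of > 10000 nM in this assay, at which 2 of the 3 values shown sit, and the gap between compound 2 and compound 3 cannot be read.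

Compound 4 `COc1ccc(/C=C\c2cc(OC)c(OC)c(OC)c2)cc1OCc1ccc(CN[C@H](C(=O)O)[C@@H](C)O)cc1` differs from compound 1 by ((1-carboxy-2-hydroxypropyl)amino)methyl in place of formyl on an aromatic carbon. Both measured replacements of the formyl group bear on this change, and both moved the number upward beyond the scatter. The account therefore expects a step of similar kind, a 3.1-fold higher number from compound 1 to compound 4 (0.49 log units; beyond the scatter), with a real chance that only a limit is reported. Compound 4 is accordingly expected to give about 15000 nM, within a range from 6000 nM to 40000 nM.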

Compound 4, half-maximal inhibitory concentration: > 10000 nM
Compound 4: a limit, no number; the forecaster's own chance of this, stated with the estimate: 70%; the middle value does not contradict the limit.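

In this assay, a third replacement of the formyl group at this place, on an aromatic carbon para to a large group, gives an at least 2.0-fold higher number from compound 1 to compound 4 (0.31 log units; beyond the scatter). Unlike the piperidine and pyrrolidine rings of the earlier replacements, the ((1-carboxy-2-hydroxypropyl)amino)methyl group has no ring, so the upward step is now seen with an open chain as well, and no compound shown with a replacement goes against it. The steps among compound 2, compound 3 and compound 4 cannot be read, and all three end at the same point: the limit of > 10000 nM in this assay, at which 3 of the 4 values shown sit.

Compound 1 therefore remains the only compound with a plain number, and the compounds shown leave open how far above it the three replacements lie. Also open, going by these compounds, is how a simple aminomethyl, a hydroxymethyl or a carboxylic acid set directly on the aromatic carbon would read in this assay.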